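A Methyl Added to a Compound at the Assay Limit

A few compounds are considered here, and "the series" means these few. Any claim that something is new, unique, unknown or untested is made for them only; others in the source may bear on it.

Values in a functional assay on L1210 cells (Mus musculus), with a stated time of 2 days; on this read-out higher numbers stand for weaker inhibition and lower numbers for stronger inhibition:
Compound 1 `O=C(Nc1ccn([C@H]2OCC=CC2=O)c(=O)n1)c1ccccc1`: 28000 nM
Compound 2 `C=C1C=CCO[C@@H]1n1ccc(NC(=O)c2ccccc2)nc1=O`: 368000 nM
Compound 3 `C=C1[C@H](O)[C@H](O)CO[C@@H]1n1ccc(O)nc1=O`: > 800000 nM (a limit, not a number)

Compound 3 sits at the limit of > 800000 nM in this assay, at which 1 of the 3 values shown sits. It therefore has a limit where the other two compounds have numbers, and no exact starting point is known for the next step.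

Compound 4 `C=C1[C@H](O)[C@H](O)CO[C@@H]1n1cc(C)c(O)nc1=O` differs from compound 3 in one place: methyl in place of hydrogen on an aromatic carbon. In words, it carries methyl in place of hydrogen on an aromatic carbon.

For the measured compounds named here, only one measured step exists in this small set, and it bears on the change only loosely. That step, a 13-fold higher number from compound 1 to compound 2 (1.12 log units; beyond the scatter), is large, but it swaps one ring group for another on an aromatic nitrogen. It shows that a structural change can move the read-out in this assay, yet it involves no methyl and a different place on the molecule. With so little to go on, no step beyond the scatter is expected, in either direction. The expected step is a number no higher from compound 3 to compound 4 (the limit leaves the size open). Compound 4 may well be reported as a limit too. The estimate for compound 4 is 800000 nM, with an expected range from 250000 nM to 1600000 nM.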

Compound 4, half-maximal inhibitory concentration: 610000 nM
Estimate against measurement, compound 4: 1.3-fold (0.12 log units) above; measured number inside the range.
By their numbers in this assay, from the lowest: compound 1; then compounds 2 and 4 (each within the scatter of the next). At a limit, above all of these: compound 3.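

In this assay compound 3 gives only a limit of the assay, > 800000 nM, and not a number. For the compounds shown here, a methyl on this aromatic carbon, ortho to the hydroxy group, gives an at least 1.3-fold lower number from compound 3 to compound 4 (0.11 log units; that floor lies within the scatter), and this is the first reading at this position: compound 4 has a real number, so the methyl does not push it past what the assay can read. How much the methyl truly changes the inhibition stays unknown, and the step can only be read as a floor because of where compound 3 stands: the limit of > 800000 nM in this assay, at which 1 of the 4 values shown sits.

From the compounds shown here alone, one step at one position cannot show a trend, so it remains open whether the same methyl would have a similar effect on the core of compound 1 or compound 2, which carry the benzoyl amide and lack the hydroxy group at this part of the ring. Going by these compounds, it is also open how this aromatic carbon would respond to a longer chain such as ethyl, or to a different kind of group such as an amine or a carboxylic acid.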